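From Methoxy to Chloro: Estimating Compound 4

A few compounds are considered here, and "the series" means these few. Any claim that something is new, unique, unknown or untested is made for them only; others in the source may bear on it.

Compound 1 `O=C(O)Cc1sc(C(c2ccc(F)cc2)c2ccc(F)cc2)nc1-c1ccnc(N2CCC2)c1`: 80%
Compound 2 `O=C(O)Cc1sc(C(c2ccc(F)cc2)c2ccc(F)cc2)nc1-c1ccco1`: 80%
Compound 3 `COc1cc(-c2nc(C(c3ccc(F)cc3)c3ccc(F)cc3)sc2CC(=O)O)ccn1`: 60%

In an in vitro functional assay on HEK285-7 cells for antagonist activity at prostaglandin D2 receptor 2 (Homo sapiens), read by BRET and beta-arrestin recruitment (a higher number here means a larger maximal response, a lower number a smaller maximal response), compound 3 stands lowest of the three measured compounds, with 60%. Its two neighbours lie higher: a number 20 percentage points lower from compound 1 to compound 3 (beyond the scatter), and a number 20 percentage points lower from compound 2 to compound 3 (beyond the scatter), while compound 1 and compound 2 themselves show no change at the digits printed from compound 1 to compound 2 (within the scatter).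

Compound 4 `O=C(O)Cc1sc(C(c2ccc(F)cc2)c2ccc(F)cc2)nc1-c1ccnc(Cl)c1` is not yet measured. Its difference from compound 3 is chloro in place of methoxy on an aromatic carbon. Within the data shown here, no measured step exchanges methoxy for chloro, so the bearing of the three known steps is indirect. The steps into compound 3 show that the group at this aromatic carbon matters: azetidin-1-yl gave a modestly higher maximal response than methoxy, and the furan-2-yl compound also sat higher. Chloro is a third kind of group at that carbon, and the data give no direction for it. The author therefore expects compound 4 to lie near compound 3 or somewhat above it, with a step of a number 10 percentage points higher from compound 3 to compound 4 (within the scatter), and estimates 70%, within 50% to 90%.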

Compound 4, largest response reached (reported as efficacy), in percent of the reference or control that the assay uses: 80%
Estimate against measurement, compound 4: 10 percentage points below; measured number inside the range.
By their numbers in this assay, from the lowest: compound 3; then compounds 1, 2 and 4 (each within the scatter of the next).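

In this assay, among these compounds, the first direct exchange at this carbon next to the ring nitrogen, chloro in place of methoxy, gives a number 20 percentage points higher from compound 3 to compound 4 (beyond the scatter). Chloro also stands level with the azetidin-1-yl group, with no change at the digits printed from compound 1 to compound 4 (within the scatter), and with the furan-2-yl compound, with no change at the digits printed from compound 2 to compound 4 (within the scatter), so among these four compounds only the methoxy compound, compound 3, stands apart at the low end. Nothing available accounts for this difference between methoxy and chloro.

Going by these compounds, what remains open is whether a longer ether such as ethoxy would stay with methoxy at the low end, or whether fluoro or methyl at this carbon would stand level with chloro. Also open, on these data alone, is how chloro would behave on this ring without the ring nitrogen beside it.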